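The compounds below may be only part of what the source reports. "The series", "measured", "known", "first", "only" and "open" are said of these compounds alone.

Measured in a functional assay on MCF7 cells (Homo sapiens) for inhibition, read by MTT assay, with a stated time of 48 h; a higher number here means a weaker inhibitor of growth, a lower number a stronger inhibitor of growth:
Compound 1 `Cn1cc(C2CC(c3ccccc3)=NN2C(=O)c2ccc(Cl)nc2)c2ccccc21`: 9250 nM
Compound 2 `COc1ccc(C(=O)N2N=C(c3ccccc3)CC2c2cn(C)c3ccccc23)cn1`: 4310 nM
Compound 3 `Cn1cc(C2CC(c3ccccc3)=NN2C(=O)c2cccnc2Cl)c2ccccc21`: > 10000 nM, a limit of the assay and not a number

Compound 2 holds the lower of the two exact numbers, 4310 nM. Compound 4 `COc1ccc2c(c1)c(C1CC(c3ccccc3)=NN1C(=O)c1ccc(OC)nc1)cn2C` differs from compound 2 by one change: methoxy in place of hydrogen on an aromatic carbon. Within the data shown here, the closest guide is a 2.1-fold lower number from compound 1 to compound 2 (0.33 log units; beyond the scatter), the only measured step that brings in a methoxy, although there it replaces chloro at another place. Among the measured compounds shown here, no measured step changes the place altered here, so only a small downward shift is expected in this assay, within the scatter. The estimated step is a 1.2-fold lower number from compound 2 to compound 4 (0.09 log units; within the scatter). For compound 4 the expected value is 3500 nM, with an estimated range of 1400 nM to 9000 nM.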

Compound 4, concentration for 50% growth inhibition: 990 nM
For compound 4 the middle estimate is 3.5-fold (0.55 log units) above the measured one; the measured number lies below the stated range.
By their numbers in this assay, from the lowest: compound 4; then compound 2; then compound 1. At a limit, above all of these: compound 3.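

Every earlier step changed the group on the carbonyl carbon, whereas this change sits on a six-membered aromatic ring of carbon only, part of a fused system of two rings. Methoxy in place of hydrogen at this place gives a 4.4-fold lower number from compound 2 to compound 4 (0.64 log units; beyond the scatter) in this assay and so makes the compound a stronger inhibitor of growth. This ring can therefore carry a substituent without loss of growth inhibition, at least in this one pair.

From the compounds shown here alone, whether an amine, a carboxylic acid or a longer chain at this place would act like methoxy stays open. Nothing shown here accounts for the size of this step.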